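Swapping a Sulfur-Bearing Group for Trifluoromethoxy

A few compounds are considered here, and "the series" means these few. Any claim that something is new, unique, unknown or untested is made for them only; others in the source may bear on it.

Compound 1 `CC(NC(=O)c1ccc(C(C)(C)C)cc1)c1ccc(C(=O)O)cc1`: 76 nM
Compound 2 `C[S+]([O-])c1ccc(CNC(=O)c2ccc(C(C)(C)C)cc2)cc1`: 1300 nM

In an assay on HeLa cells with Bile acid receptor (Homo sapiens) as the target, read by a luciferase reporter, with a stated time of 24 h (on this read-out lower numbers stand for an effect already at smaller amounts and higher numbers for an effect only at larger amounts of compound), compound 1 gives 76 nM, while compound 2 gives 1300 nM. Compound 2 therefore carries the higher of the two numbers, and its gap to compound 1 lies beyond the usual scatter. Compound 3 `CC(C)(C)c1ccc(C(=O)NCc2ccc(OC(F)(F)F)cc2)cc1` differs from compound 2 in a single place: a group of 5 heavy atoms (1 carbon, 1 oxygen, 3 fluorine; no ring) in place of a group of 3 heavy atoms (1 carbon, 1 oxygen, 1 sulfur; no ring), on an aromatic carbon. Going by the values given here, no measured pair shows this kind of exchange, so the expected step is modest, with a slightly lower number or none beyond the scatter. Compound 3 is expected to give 900 nM, ranging from 250 nM to 3500 nM. The expected step of a 1.4-fold lower number from compound 2 to compound 3 (0.16 log units; within the scatter) is thus small.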

Compound 3, half-maximal effective concentration: 160 nM
For compound 3 the middle estimate is 5.6-fold (0.75 log units) above the measured one; the measured number lies below the stated range.
By their numbers in this assay, from the lowest: compound 1; then compound 3; then compound 2.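

At this aromatic carbon, para to a large group, the exchange of the sulfur-bearing group for trifluoromethoxy gives an 8.1-fold lower number from compound 2 to compound 3 (0.91 log units; beyond the scatter) in this assay and so shows that this position responds to a change of group while the rest of the structure stays the same. This is the first single-place step among these compounds. No available evidence accounts for the size of this step.

Going by these compounds, whether a methoxy group, a chlorine atom or a carboxylic acid at this position would give a lower or higher number remains open. On these data alone, it is also open whether trifluoromethyl would match trifluoromethoxy here.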